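The source may hold more compounds than are shown below. What is called first, only, known or untested is meant among the compounds shown, and "the series" means these compounds.

Values so far in an ADME assay on PC-12 cells (Rattus norvegicus) for cytotoxicity, read by MTT assay, with a stated time of 24 h; on this read-out lower numbers stand for higher toxicity in this test and higher numbers for lower toxicity in this test
Compound 1 `COc1cccc(N2CCN(CC#CCOC(=O)c3sc4ncnc(N5CCCCC5)c4c3C)CC2)c1` gives 144 ug/mL
Compound 2 `Cc1c(C(=O)OCC#CCN2CCN(c3cc(C4CC4)ccc3C#N)CC2)sc2ncnc(N3CCCCC3)c12` gives 148 ug/mL
Compound 3 `Cc1ccc(-c2nnc(-c3sc4ncnc(N5CCCCC5)c4c3C)o2)cc1` gives 161 ug/mL

In this assay compound 3 at 161 ug/mL stands level with the other two, within the scatter of both. Compound 4 `Cc1c(-c2nnc(-c3ccc(Cl)cc3)o2)sc2ncnc(N3CCCCC3)c12` has chloro in place of methyl on an aromatic carbon of compound 3 (chloro in place of methyl on an aromatic carbon). Going by the values given here, the one measured step (a 1.0-fold higher number from compound 1 to compound 2 (0.01 log units; within the scatter)) concerns a different group and lies within the scatter. Among the compounds with values here, no measured pair tests this swap directly, so no step beyond the scatter is expected. The expected step is a 1.0-fold lower number from compound 3 to compound 4 (0.02 log units; within the scatter) and remains within the scatter. Compound 4 is therefore estimated at 155 ug/mL (95 ug/mL to 250 ug/mL).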

Compound 4, half-maximal cytotoxic concentration: 151 ug/mL
Compound 4: the middle estimate sits 1.0-fold (0.01 log units) above what was measured, within the range that was stated.
By their numbers in this assay, from the lowest: compounds 1, 2, 4 and 3 (each within the scatter of the next).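

The swap from 4-methylphenyl to 4-chlorophenyl gives a 1.1-fold lower number from compound 3 to compound 4 (0.03 log units; within the scatter) in this assay, so the two groups cannot be told apart in this test at this place on the ring. Going by these compounds alone, this is the first measured step at this position, as the earlier step concerned a different group. Nothing at hand bears on a cause for this result. The compounds shown leave open whether an amine or a carboxylic acid at this same place would also stay within the scatter. From the compounds shown here alone, a longer chain there remains equally open.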